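The compounds below may be only part of what the source reports. "The series", "measured", "known", "first", "only" and "open" are said of these compounds alone.

Measured compounds, in a functional assay on NCI-H661 cells (Homo sapiens) for antiproliferative activity, read by MTT assay, with a stated time of 72 h; a higher number here means a weaker inhibitor of growth, a lower number a stronger inhibitor of growth:
compound 1 `O=C(COc1ccc2c(=O)cc(-c3ccccc3)oc2c1)Nc1ccc2ccccc2c1` gives > 10000 nM, a limit of the assay
compound 2 `O=C(COc1c(-c2ccccc2)oc2ccccc2c1=O)Nc1ccccc1` gives > 10000 nM, a limit of the assay
compound 3 `COc1ccc(NC(=O)COc2c(-c3ccccc3)oc3ccccc3c2=O)cc1` gives 6740 nM

Compound 1 stands at the limit of this assay, so only a floor is known for it: the limit of > 10000 nM in this assay, at which 2 of the 3 values shown sit. Going by the values given here, compound 3 is the one measured compound with a number, and even that number is high. Compound 4 `O=C(COc1ccc2c(=O)cc(-c3ccccc3)oc2c1)Nc1ccc(F)cc1` differs from compound 1 by 4-fluorophenyl in place of naphthalen-2-yl on an amide-type nitrogen.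

Among the compounds with values here, the single measured step, an at least 1.4-fold lower number from compound 2 to compound 3 (0.17 log units; that floor lies within the scatter), concerns a methoxy on the aryl amide of the other core arrangement, lies within the scatter, and says nothing about exchanging a naphthalen-2-yl for a 4-fluorophenyl. Within the data shown here, because compound 1 sits at > 10000 nM, no computed step from it to compound 4 is possible; any value for compound 4 can only be expected to stay in the weak range all three measured compounds occupy. Compound 4 is therefore estimated at 9000 nM, between 4000 nM and 20000 nM, which means an expected step of an at least 1.1-fold lower number from compound 1 to compound 4 (0.04 log units; that floor lies within the scatter), with a real chance that this assay again reports only a limit.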

Compound 4, concentration for 50% growth inhibition: 5770 nM
For compound 4 the middle estimate is 1.6-fold (0.19 log units) above the measured one; low and high end bracket the measured number.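

On the amide-type nitrogen of the core of compound 1, 4-fluorophenyl in place of naphthalen-2-yl gives the first number on this core among the compounds shown, with an at least 1.7-fold lower number from compound 1 to compound 4 (0.23 log units; that floor lies within the scatter). In this assay compound 4 gives 5770 nM, so a single aromatic ring of carbon at this place still leaves a high value, though one that can be read as a number. The step is a floor and cannot be sized further: the limit of > 10000 nM in this assay, at which 2 of the 4 values shown sit.

The compounds shown do not separate the fluorine from the loss of the second aromatic ring, a question that a plain phenyl on this core would address. On these data alone, how an amine or a carboxylic acid on that aromatic ring, or a longer chain carrying the amide, would read in this assay also stays open.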